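Dropping a chloro group from a trifluoromethyl-bearing amide

The source may report more compounds than this note shows. Statements on the series, on what has been measured and on what is new or still open speak of the compounds shown alone.

Measured so far:
compound 1, `O=C(Nc1cccc(-n2cc(-c3ccncc3)c(-c3ccc(Cl)c(O)c3)n2)c1)Nc1ccc(Cl)c(Cl)c1`: 1700 nM
compound 2, `COc1cc(-c2nn(-c3cccc(NC(=O)c4ccc(Cl)c(C(F)(F)F)c4)c3)cc2-c2ccncc2)ccc1Cl`: 7540 nM

Of the compounds shown here, two have been tested in a functional assay on BT-549 cells (Homo sapiens) for inhibition, read by sulforhodamine B assay, with a stated time of 48 h; on this read-out higher numbers stand for weaker inhibition of growth and lower numbers for stronger inhibition of growth. Compound 1 gives 1700 nM, while compound 2 gives 7540 nM. Compound 2 therefore has the higher of the two numbers, and its gap to compound 1 lies beyond the usual scatter, so compound 2 is the weaker of the pair on this read-out. Compound 3, `COc1cc(-c2nn(-c3cccc(NC(=O)c4cccc(C(F)(F)F)c4)c3)cc2-c2ccncc2)ccc1Cl`, has not yet been measured. It differs from compound 2 by hydrogen in place of chloro on an aromatic carbon. Nothing measured here shows how this particular change affects the growth inhibition, so the step from compound 2 is expected to be small, most likely a slight weakening, with no change beyond the scatter also possible: a 1.5-fold higher number from compound 2 to compound 3 (0.16 log units; within the scatter) is the expected step. Compound 3 is estimated at 11000 nM in this assay, with a plausible range of 3500 nM to 35000 nM.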

Compound 3, concentration for 50% growth inhibition: 2870 nM
Estimate against measurement, compound 3: 3.8-fold (0.58 log units) above; measured number below the stated range.
By their numbers in this assay, from the lowest: compounds 1 and 3 (each within the scatter of the next); then compound 2.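

In this assay, replacing the chloro group with hydrogen gives a 2.6-fold lower number from compound 2 to compound 3 (0.42 log units; beyond the scatter) and so turns 4-chloro-3-(trifluoromethyl)phenyl into 3-(trifluoromethyl)phenyl with a modest gain in growth inhibition. For this pair, then, the chloro group on the aromatic carbon ortho to the trifluoromethyl group and para to a large group is not needed, and the compound does better with hydrogen there. Nothing measured here explains why the number falls.

As far as these compounds go, only chloro and hydrogen have been compared at this position, so it remains open whether a fluoro group, a nitrile or an amine there would give a lower or a higher number than hydrogen. It is also unknown whether removing a chloro group would have a similar effect on the dichlorophenyl urea of compound 1.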